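From cyclopentylamino to methylamino on a shared core

A few compounds are considered here, and "the series" means these few. Any claim that something is new, unique, unknown or untested is made for them only; others in the source may bear on it.

Compound 1 `COc1ncnc2c1ncn2C1O[C@H](CO)[C@H](O[C@@H]2OC(CO)[C@H](OP(=O)(O)O)C(OP(=O)(O)O)[C@@H]2O)[C@@H]1OP(=O)(O)O` gives 19 nM
Compound 2 `O=P(O)(O)OC1[C@@H](OP(=O)(O)O)C(CO)O[C@@H](O[C@@H]2[C@H](OP(=O)(O)O)C(n3cnc4c(NC5CCCC5)ncnc43)O[C@@H]2CO)[C@H]1O` gives 13 nM

In a functional assay (Hepatocyte) with Rattus norvegicus as the target (a higher number here means that more compound is needed for the effect, a lower number that less compound is needed), compound 2 gives 13 nM and stands within the scatter of compound 1. Compound 3 `CNc1ncnc2c1ncn2C1O[C@H](CO)[C@H](O[C@@H]2OC(CO)[C@H](OP(=O)(O)O)C(OP(=O)(O)O)[C@@H]2O)[C@@H]1OP(=O)(O)O` differs from compound 2 by methyl in place of cyclopentyl on a nitrogen on an aromatic ring with methyl in place of cyclopentyl on a nitrogen on an aromatic ring. Within the data shown here, one measured step bears on this: a 1.5-fold lower number from compound 1 to compound 2 (0.16 log units; within the scatter) with cyclopentylamino in place of methoxy on an aromatic carbon. Among the measured compounds shown here, no measured step covers methylamino itself, so only a weak guide exists. No step beyond the scatter is expected in this assay in either direction. The estimated change is a 1.2-fold higher number from compound 2 to compound 3 (0.06 log units; within the scatter) and stays within the scatter. Compound 3 is expected at 15 nM with 6 nM to 40 nM as its estimated range.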

Compound 3, half-maximal effective concentration: 13 nM
Compound 3: the middle estimate sits 1.2-fold (0.06 log units) above what was measured; the measured number falls inside the stated range.
By their numbers in this assay, from the lowest: compounds 2, 3 and 1 (each within the scatter of the next).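

Replacing cyclopentyl with methyl on a nitrogen on an aromatic ring gives no change at the digits printed from compound 2 to compound 3 (within the scatter) in this assay, so the five-membered ring is not needed to hold the number at this level. Methylamino in place of methoxy on an aromatic carbon gives a 1.5-fold lower number from compound 1 to compound 3 (0.16 log units; within the scatter), which leaves methoxy, methylamino and cyclopentylamino all within the scatter of one another at this position. Nothing available explains this flat result. As far as these compounds go, whether an unsubstituted amine, a carboxylic acid or a longer chain at this place would move the number beyond the scatter remains open.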